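From a methyloxane to a piperidine on a shared core

The compounds below may be only part of what the source reports. "The series", "measured", "known", "first", "only" and "open" are said of these compounds alone.

Compound 1 `CC(C)CN(c1ccc(C(C)(C)C)cc1)S(=O)(=O)c1ccc2c(c1)C(=O)CC(C1CCOCC1)O2` gives 4.97
Compound 2 `CC(C)CN(c1cc2ccccc2s1)S(=O)(=O)c1ccc2c(c1)C(=O)CC(C1CCOCC1)O2` gives 4.01
Compound 3 `CCc1ccc(N(CC(C)C)S(=O)(=O)c2ccc3c(c2)C(=O)CC(C2(C)CCOCC2)O3)cc1` gives 4.71

These three compounds have been read in a physicochemical assay for lipophilicity, at pH 7.4 (a higher number here means a more lipophilic compound, a lower number a more polar compound), and compound 4 `CCc1ccc(N(CC(C)C)S(=O)(=O)c2ccc3c(c2)C(=O)CC(C2CCNCC2)O3)cc1` is still to be measured there. Compound 3 at 4.71 lies within the scatter of compound 1 at 4.97 and stands above compound 2 at 4.01 by a gap beyond the scatter.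

Going on to compound 4 puts piperidin-4-yl in place of 4-methyloxan-4-yl on a saturated ring carbon, next to the ring oxygen, and the exchange amounts to piperidin-4-yl in place of 4-methyloxan-4-yl on a saturated ring carbon in all. Among the compounds with values here, the one measured step, a number 0.96 log units lower from compound 1 to compound 2 (beyond the scatter) for 1-benzothiophen-2-yl in place of 4-(tert-butyl)phenyl on a sulfonamide nitrogen, was made in another place and offers only a yardstick of size.

Within the data shown here, no measured compound carries piperidin-4-yl, so the direction rests on the structural change alone. A fall from compound 3 at 4.71 is expected, larger than that yardstick. The expected step is a number 1.51 log units lower from compound 3 to compound 4 (beyond the scatter). Nothing in the data so far tests it. In this assay compound 4 is estimated at 3.2 with a range of 2.4 to 4 expected around it.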

Compound 4, distribution coefficient: 2.21
For compound 4 the middle estimate is 0.99 log units above the measured one; measured number outside the range, below it.
By their numbers in this assay, from the lowest: compound 4; then compound 2; then compounds 3 and 1 (each within the scatter of the next).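

In this assay, within the data shown here, the exchange of 4-methyloxan-4-yl for piperidin-4-yl on the saturated ring carbon gives a number 2.50 log units lower from compound 3 to compound 4 (beyond the scatter), so this position, which no earlier step touched, can move the number a long way. The only earlier step, a number 0.96 log units lower from compound 1 to compound 2 (beyond the scatter), was made on a sulfonamide nitrogen and no longer marks the largest shift seen from a single change among these compounds. The entering group counts 1 hydrogen-bond donor where the leaving group counts 0, and it also lacks the methyl group, but no evidence is at hand that accounts for the size of this step.

Since the hetero atom and the methyl group change together, the compounds shown leave open how the step divides between them, which 4-methylpiperidin-4-yl or oxan-4-yl on the core of compound 3 would settle. They also leave open whether the number stays this low when the piperidine nitrogen carries a methyl group or an acetyl group, making it a tertiary amine or an amide.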